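This account rests on a few compounds, and the source may have more. Where it says the series, first, only, none or still open, it means among the compounds named here.

Measured compounds:
compound 1 `CCCCn1ccnc1-c1cc(OC)c(OC)c(OC)c1` — > 100000 nM
compound 2 `COc1cc(OC)cc(-n2ccnc2-c2cc(OC)c(OC)c(OC)c2)c1` — > 100000 nM

In a functional assay on HCT-15 cells (Homo sapiens) for antiproliferative activity, read by MTT assay, with a stated time of 72 h (on this read-out lower numbers stand for stronger inhibition and higher numbers for weaker inhibition), compound 1 gives > 100000 nM; this is a limit of the assay and not a number. Compound 2 likewise reaches only a limit, > 100000 nM. Both measured values thus rest at the limit of > 100000 nM in this assay, at which 2 of the 2 values shown sit, so compound 1 stands at the limit together with compound 2, and no order between the two can be read from the numbers shown.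

Compound 3 `COc1ccc(-n2ccnc2-c2cc(OC)c(OC)c(OC)c2)cc1` is still to be measured. It differs from compound 1 in one place: 4-methoxyphenyl in place of butyl on an aromatic nitrogen. The butyl chain gives way to 4-methoxyphenyl on the ring nitrogen. With compound 1 and compound 2 both sitting at the limit, compound 3 is expected to remain at the limit as well, so no step beyond the scatter is expected, a number no higher from compound 1 to compound 3 (the limit leaves the size open). Compound 3 is estimated at 100000 nM, within 30000 nM to 300000 nM.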

Compound 3, half-maximal inhibitory concentration: 1300 nM
For compound 3 the middle estimate is 77-fold (1.89 log units) above the measured one; the measured number lies below the stated range.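

Placing 4-methoxyphenyl in place of butyl on the aromatic nitrogen gives an at least 76-fold lower number from compound 1 to compound 3 (1.88 log units; beyond the scatter) in this assay and yields the only value shown that is a number and not a limit. The substituent at this position can therefore move the read-out well beyond the scatter, which the two earlier compounds, both at the limit, could not show. Compound 2 gives > 100000 nM in this assay as a limit of the assay, so a six-membered aromatic ring on this nitrogen does not suffice alone and its methoxy substitution matters: the limit of > 100000 nM in this assay, at which 2 of the 3 values shown sit.

From the compounds shown here alone, the full size of the step stays open, the value of compound 1 being a limit. Going by these compounds, whether an unsubstituted phenyl, a 4-hydroxyphenyl or a benzyl on the same nitrogen would also give a number also remains open.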